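The compounds below may be only part of what the source reports. "The series", "measured", "known", "first", "only" and "open" are said of these compounds alone.

Measured compounds:
Compound 1, `CC1(C)C=C(n2ccccc2=O)c2cc(C(=O)c3ccc(O)cc3)ccc2O1`, gives 5.87
Compound 2, `CC1(C)C=C(n2ccccc2=O)c2cc(O)ccc2O1`, gives 5.31

Both numbers come from a functional assay (trachea) with Rattus norvegicus as the target; on this read-out higher numbers stand for higher potency (the scale is a negative logarithm) and lower numbers for lower potency. For the measured compounds named here, compound 2 stands at the lower of the two values; compound 1 sits above it, and the only measured step, a number 0.56 log units lower from compound 1 to compound 2 (beyond the scatter), separates them. That step swapped a large (4-hydroxyphenyl)carbonyl group for a small hydroxy group on the aromatic carbon of the shared core and cost potency.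

Compound 3, `CC1(C)C=C(n2ccccc2=O)c2cc(C#N)ccc2O1`, has not yet been measured in this assay. It differs from compound 2 by cyano in place of hydroxy on an aromatic carbon. Going by the values given here, the one step that bears on it is a number 0.56 log units lower from compound 1 to compound 2 (beyond the scatter), which shows that a hydroxy at this position gave the weaker compound of the two; no measured compound carries a cyano group, so the data say nothing directly about it. The hydroxy's hydrogen-bond donor is lost while one acceptor remains.

With so little to lean on, the expected step is small and uncertain: the estimate for compound 3 means a number 0.19 log units higher from compound 2 to compound 3 (within the scatter), a change not clearly beyond the scatter. Compound 3 is therefore expected to give about 5.5, within a range of 5 to 6.1.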

Compound 3, logarithm of the reciprocal of the active concentration, log(1/C): 7.1
Compound 3: middle estimate off by 1.60 log units, on the low side, and the stated range ends below it.
By their numbers in this assay, from the lowest: compound 2; then compound 1; then compound 3.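

In this assay, putting cyano in place of hydroxy on this aromatic carbon gives a number 1.79 log units higher from compound 2 to compound 3 (beyond the scatter), and putting it in place of (4-hydroxyphenyl)carbonyl gives a number 1.23 log units higher from compound 1 to compound 3 (beyond the scatter), so the highest of the three numbers belongs to neither of the earlier groups. The earlier step alone could have suggested that the large (4-hydroxyphenyl)carbonyl group was what lifted potency at this position, but these steps show that it is not needed, and that a two-atom cyano group with no hydrogen-bond donor can outdo both groups that carry a hydroxy. Nothing shown here accounts for why this one change has so large an effect.

On these data alone, it remains open whether the high number of compound 3 at 7.1 is special to cyano or would also appear with other groups on this carbon, such as a carboxylic acid, an amine, a nitro group or trifluoromethyl. Also open, as far as these compounds go, is whether a longer chain ending in a nitrile, such as cyanomethyl, would keep that potency or lose it.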